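The source may report more compounds than this note shows. Statements on the series, on what has been measured and on what is new or still open speak of the compounds shown alone.

Working notes on the series. Compound 1 `O=[N+]([O-])c1cccc(-c2nn(-c3ccccc3)cc2C(Nc2nc3ccccc3s2)c2c(O)ccc3ccccc23)c1`, compound 2 `COc1ccc2nc(NC(c3cn(-c4ccccc4)nc3-c3cccc([N+](=O)[O-])c3)c3c(O)ccc4ccccc34)sc2c1` and compound 3 `COc1cccc(-c2nn(-c3ccccc3)cc2C(Nc2nc3ccc(OC)cc3s2)c2c(O)ccc3ccccc23)c1` have been tested in a functional assay on A549 cells (Homo sapiens) for antiproliferative activity, read by MTT assay, with a stated time of 48 h; a higher number here means a weaker inhibitor, a lower number a stronger inhibitor. In this assay compound 1 gives 32000 nM, compound 2 gives 52200 nM and compound 3 gives 88100 nM. The core of compound 3 differs from that of compound 2 by methoxy in place of nitro on an aromatic carbon, and this gives a 1.7-fold higher number from compound 2 to compound 3 (0.23 log units; within the scatter). Compound 4 `COc1ccc2nc(NC(c3cn(-c4ccccc4)nc3-c3ccccc3)c3c(O)ccc4ccccc34)sc2c1` has not yet been measured; it differs from compound 3 by hydrogen in place of methoxy on an aromatic carbon, which is the same kind of change as hydrogen in place of methoxy on an aromatic carbon, where the step was a 1.6-fold lower number from compound 2 to compound 1 (0.21 log units; within the scatter). Around the place the two differ: in the measured pair the aromatic carbon is part of a fused or bridged system of two rings, meta to a fused ring and para to a fused ring, whereas in compound 4 the ring is of carbon only and the carbon is meta to a large group. Resting on compound 2 and compound 1 and the step of a 1.6-fold lower number from compound 2 to compound 1 (0.21 log units; within the scatter), a similarly small step is expected, a 1.4-fold lower number from compound 3 to compound 4 (0.13 log units; within the scatter). Compound 4 is estimated at 65000 nM, with a range from 30000 nM to 140000 nM.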

Compound 4, half-maximal inhibitory concentration: 44600 nM
Compound 4: the middle estimate sits 1.5-fold (0.16 log units) above what was measured, and the stated range covers the measured number.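

In this assay, hydrogen in place of methoxy, read as 3-methoxyphenyl to phenyl, gives a 2.0-fold lower number from compound 3 to compound 4 (0.30 log units; within the scatter), and hydrogen in place of nitro gives a 1.2-fold lower number from compound 2 to compound 4 (0.07 log units; within the scatter). Hydrogen in place of methoxy reads alike on the two cores, with no difference between the steps that stands out from the scatter: the same change on two cores in this assay, a 1.6-fold lower number (0.21 log units; within the scatter) from compound 2 to compound 1 and a 2.0-fold lower number (0.30 log units; within the scatter) from compound 3 to compound 4, 1.2-fold (0.08 log units) apart, within the scatter of two such steps. This shows that the change carried over between these two cores without a measurable difference; it does not show that methoxy has any real effect on the number, as each of these steps lies within the scatter, and two pairs give no rule for the series.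

Left open is whether any other replacement for methoxy, such as an amine, a carboxylic acid or a longer chain, would give a step beyond the scatter. Also open, on these data alone, is whether hydrogen in place of methoxy would read the same way on a third core.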